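A few compounds are considered here, and "the series" means these few. Any claim that something is new, unique, unknown or untested is made for them only; others in the source may bear on it.

Compound 1 `O=C(NO)c1ccc(-c2cn([C@@H]3C[C@H](C(=O)O)N(Cc4ccccc4)C3)nn2)cc1` gives < 10% in an assay on Sf9 cells for inhibition of histone deacetylase 11 (Homo sapiens), read by fluorescence, tested at 0.5 uM (on this read-out higher numbers stand for more inhibition at the one concentration tested (going by the name of the read-out) and lower numbers for less inhibition), a limit of the assay rather than a number.
Compound 2 `O=C(NO)c1cccc(-c2cn([C@H]3C[C@H](C(=O)O)N(Cc4ccccc4)C3)nn2)c1` gives < 10% in this assay, likewise a limit of the assay.

Among the measured compounds shown here, compound 2 therefore stands at the floor of what the assay reports, and the only evidence so far is the limit of < 10% in this assay, at which 2 of the 2 values shown sit. Compound 3 `O=C(NO)c1cccc(-c2cn([C@@H]3C[C@H](C(=O)O)N(Cc4ccccc4)C3)nn2)c1` has not yet been measured in this assay. It differs from compound 2 by the two compounds have the same atoms and bonds and differ only in configuration as drawn: 1 of 2 stereo elements differ; a stereocentre at a saturated ring carbon is drawn S in compound 2 and R in compound 3. For the measured compounds named here, no measured step accompanies this change, so no movement beyond the scatter is expected in either direction. Compound 3 is expected to give 5%, within 0% to 12%. The expected step is a step that the limit leaves unreadable from compound 2 to compound 3, no larger than the scatter.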

Compound 3, a percentage reported as inhibition, at one concentration (the size of the read-out at that concentration, not a potency): < 10%
Compound 3: no number, only a limit; the forecaster's own chance of this, stated with the estimate: 85%; the middle value lies beyond the limit too.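

Compound 1, compound 2 and compound 3 are all reported only as limits of the assay, so neither step to compound 3 can be read. The compounds shown leave open whether the configuration at the saturated ring carbon, or 3-(hydroxycarbamoyl)phenyl in place of 4-(hydroxycarbamoyl)phenyl, affects inhibition at all.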